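Trifluoromethyl for methyl on a weakly active quinoline series

A few compounds are considered here, and "the series" means these few. Any claim that something is new, unique, unknown or untested is made for them only; others in the source may bear on it.

The compounds share one core and differ only at the end of the chain and at the distal aromatic ring. In a functional assay on COLO 205 cells (Homo sapiens) for inhibition, read by MTT assay, with a stated time of 24 h (on this read-out lower numbers stand for stronger inhibition and higher numbers for weaker inhibition), compound 1 `CCCc1cc2ccccc2nc1-c1cc(-c2ccccc2)no1` gives 48900 nM. Compound 2 `CCCc1cc2ccccc2nc1-c1cc(-c2ccc(C)cc2)no1` reaches only a limit of the assay in this assay, > 100000 nM, not a number. Compound 3 `CCCCc1cc2ccccc2nc1-c1cc(-c2ccc(C)cc2)no1` likewise shows only a limit in this assay, > 100000 nM. For the measured compounds named here, the step of an at least 2.0-fold higher number from compound 1 to compound 2 (0.31 log units; beyond the scatter) is the one measured change at the distal ring, and its direction is toward weaker inhibition; the step that the two limits leave unreadable from compound 2 to compound 3 cannot be sized, since the limit of > 100000 nM in this assay, at which 2 of the 3 values shown sit, caps both ends. Compound 2 therefore stands at the top of the numbers shown, with no numeric value of its own.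

Compound 4 `CCCc1cc2ccccc2nc1-c1cc(-c2ccc(C(F)(F)F)cc2)no1` differs from compound 2 by trifluoromethyl in place of methyl on an aromatic carbon. Going by the values given here, only the step from compound 1 to compound 2 bears on a change at this place, and it moved the number upward beyond the scatter. Compound 2 already sits at the limit, so a further reading above it cannot be resolved; compound 4 is expected to remain near that limit, with the expected step that the limit leaves unreadable from compound 2 to compound 4 not readable. The estimate for compound 4 in this assay is 120000 nM, within 40000 nM to 400000 nM.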

Compound 4, half-maximal inhibitory concentration: 42200 nM
Beside the measured number, compound 4's estimate is 2.8-fold (0.45 log units) above it; low and high end bracket the measured number.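

For the compounds shown here, at this aromatic carbon the outcome depends on which group is placed there, which the earlier compounds could not show: in this assay, trifluoromethyl in place of methyl gives an at least 2.3-fold lower number from compound 2 to compound 4 (0.37 log units; beyond the scatter), so the loss seen with methyl does not extend to every group at this place. Trifluoromethyl in place of hydrogen gives a 1.2-fold lower number from compound 1 to compound 4 (0.06 log units; within the scatter), which leaves that pair level within the usual scatter, so this group brings neither a gain nor a loss that can be read against the unsubstituted ring. Compound 2 carries only a limit of the assay, and the step away from it gives a minimum size and no exact one because of that limit: the limit of > 100000 nM in this assay, at which 2 of the 4 values shown sit.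

As far as these compounds go, whether any group at this carbon, such as an amine or a carboxylic acid, would move the number beyond the scatter from that of compound 1 stays open. Also open is what a longer chain does alongside trifluoromethyl, since the one chain step shown lies between two limits and cannot be read.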